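The source may hold more compounds than are shown below. What is called first, only, known or untested is meant among the compounds shown, and "the series" means these compounds.

Measured so far:
compound 1 `CNC(=O)c1c(O)c2cccnc2n(-c2ccccc2)c1=O`, a functional assay on the whole organism for inhibition, with Rattus norvegicus as the target, read by cytopathic effect and paw edema, at a dose of 100 mg/kg by the oral route (on this read-out higher numbers stand for more inhibition at the one dose given (going by the name of the read-out) and lower numbers for less inhibition), 21%
compound 2 `COc1cccc(NC(=O)c2c(O)c3cccnc3n(-c3ccccc3)c2=O)c1`, 20.7%

Compound 1 and compound 2 lie within the usual scatter of each other: the step of a number 0.3 percentage points lower from compound 1 to compound 2 (within the scatter) is the only one on record, and it shows that replacing methyl on the amide-type nitrogen with 3-methoxyphenyl leaves the read-out unchanged. Compound 3 `O=C(Nc1nccs1)c1c(O)c2cccnc2n(-c2ccccc2)c1=O` carries the same core with a different substituent at that position: 1,3-thiazol-2-yl in place of methyl on an amide-type nitrogen. For the measured compounds named here, the one measured step bears on this change only loosely, since a ring again enters at the amide-type nitrogen, and it was flat. An unchanged read-out is therefore expected, a number 1 percentage points higher from compound 1 to compound 3 (within the scatter), with wide uncertainty from so little data. Compound 3 is estimated at 22%, between 8% and 40%.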

Compound 3, a percentage reported as inhibition, in the whole organism at one dose (the size of the read-out at that dose, not a potency): 2.5%
For compound 3 the middle estimate is 19.5 percentage points above the measured one, outside the stated range (below it).
By their numbers in this assay, from the lowest: compound 3; then compounds 2 and 1 (each within the scatter of the next).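

In this assay the group on the amide-type nitrogen does matter: 1,3-thiazol-2-yl in place of methyl gives (a number 18.5 percentage points lower from compound 1 to compound 3 (beyond the scatter)), and in place of 3-methoxyphenyl it gives (a number 18.2 percentage points lower from compound 2 to compound 3 (beyond the scatter)). A ring at this nitrogen is thus not neutral as such, since 3-methoxyphenyl stays within the scatter of methyl and 1,3-thiazol-2-yl does not. Nothing available explains the drop.

From the compounds shown here alone, whether the drop follows the ring's nitrogen, its sulfur or the five-membered ring itself stays open. An unsubstituted phenyl, a pyridin-2-yl or a thiophen-2-yl on the same nitrogen would bear on this.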